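A few compounds are considered here, and "the series" means these few. Any claim that something is new, unique, unknown or untested is made for them only; others in the source may bear on it.

Compound 1, with the structure `Cc1ccc(NC(=O)/C=C/C(=O)N2C/C(=C\c3ccccc3)C(=O)/C(=C/c3ccccc3)C2)cc1`, and compound 2, with the structure `O=C(/C=C/C(=O)N1C/C(=C\c2ccccc2)C(=O)/C(=C/c2ccccc2)C1)Nc1ccccc1`, share one core and differ in a single spot. Compound 3, with the structure `O=C(/C=C/C(=O)N1C/C(=C\c2ccc([N+](=O)[O-])cc2)C(=O)/C(=C/c2ccc([N+](=O)[O-])cc2)C1)Nc1ccccc1`, is built on another core, and the difference between the two cores is not broken down here. In a functional assay on L1210 cells (Mus musculus) for cytotoxicity (on this read-out lower numbers stand for stronger inhibition and higher numbers for weaker inhibition), compound 2 gives 3600 nM. In this assay compound 1 gives 5800 nM, and compound 3 gives 1800 nM. The number for compound 3 stands below that of compound 1 by a gap beyond the usual scatter, while compound 3 and compound 2 lie within the scatter of each other, so no order between those two can be read.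

Going by the values given here, the only change from compound 2 to compound 1 is methyl in place of hydrogen on an aromatic carbon, and it made a 1.6-fold higher number from compound 2 to compound 1 (0.21 log units; within the scatter).

Compound 4, with the structure `Cc1ccc(NC(=O)/C=C/C(=O)N2C/C(=C\c3ccc([N+](=O)[O-])cc3)C(=O)/C(=C/c3ccc([N+](=O)[O-])cc3)C2)cc1`, has not been measured. Among the compounds with values here, it differs from compound 3 by methyl in place of hydrogen on an aromatic carbon, which is the same change as the one from compound 2 to compound 1, at the same kind of place. The step from compound 3 to compound 4 in this assay is therefore expected to be a 1.6-fold higher number from compound 3 to compound 4 (0.21 log units; within the scatter), because the same change on the other core made a 1.6-fold higher number from compound 2 to compound 1 (0.21 log units; within the scatter), a step that stayed within the scatter. For compound 4 the expected number in this assay is 2900 nM, most likely between 1400 nM and 6000 nM.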

Compound 4, half-maximal inhibitory concentration: 4400 nM
Compound 4: middle estimate off by 1.5-fold (0.18 log units), on the low side; measured number inside the range.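

Turning the anilino group into (4-methylphenyl)amino on the core of compound 3 gave, in this assay, a 2.4-fold higher number from compound 3 to compound 4 (0.39 log units; beyond the scatter). This step clears the usual scatter, whereas the step for the same change on the core of compound 1 does not, but that contrast alone does not make the two steps different, and set side by side they cannot be told apart: the same change on two cores in this assay, a 1.6-fold higher number (0.21 log units; within the scatter) from compound 2 to compound 1 and a 2.4-fold higher number (0.39 log units; beyond the scatter) from compound 3 to compound 4, 1.5-fold (0.18 log units) apart, within the scatter of two such steps

So within this small set, the size of the methyl step on one core was a fair guide to its size on the other, although this rests on just one pair of compounds per core and does not show that the change would behave alike on any further core, nor does it explain why the number moves at all.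

The compounds shown compare only hydrogen and methyl on this aromatic ring, so it stays open whether a chlorine atom, a methoxy group, an ethyl group or a carboxylic acid in the same place would also carry from one core to the other. On these data alone, it also stays open how such a step would look on a core bearing something other than the nitro groups of compound 3, such as an amine.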